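Branching the Ethyl Chain: A Small Change on Compound 1

The source may report more compounds than this note shows. Statements on the series, on what has been measured and on what is new or still open speak of the compounds shown alone.

Compound 1 `CCc1cccc2ccc(-c3ccc(C(/C=C4\OC(=O)NC4=O)(CC)CC)c(=O)[nH]3)cc12` is one of three compounds tested in an ADME assay on microsomes from liver (Homo sapiens) for metabolic stability (a lower number here means that the compound disappears faster, a higher number that the compound lasts longer), a test that follows how long a compound survives in the presence of liver enzymes. In this assay, within the data shown here, compound 1 gives 0.178 h, the only definite number among the three. Compound 2 `O=C1NC(=O)/C(=C/C2(c3ccc(-c4ccc5cccc(F)c5c4)[nH]c3=O)CCCC2)O1` gives > 3 h in this assay, which is a limit of the test rather than a number. Compound 3 `CCn1ncc2c(F)cc(-c3ccc(C(/C=C4\OC(=O)NC4=O)(CC)CC)c(=O)[nH]3)cc21` likewise gives > 3 h in this assay, again a limit. Two of the three readings thus sit at the limit of > 3 h in this assay, at which 2 of the 3 values shown sit. Compound 1 stands alone as the one whose half-life was short enough to be read as a number.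

Compound 4 `CCC(/C=C1\OC(=O)NC1=O)(CC)c1ccc(-c2ccc3cccc(C(C)C)c3c2)[nH]c1=O` has not yet been tested. It differs from compound 1 in one place: methyl in place of hydrogen on a saturated chain carbon bound to an aromatic carbon and a saturated chain carbon. The other two compounds differ from compound 1 in more than this one place, so their limits give no direct measure of this step. The change is expected to lengthen the half-life only modestly, an estimated 1.7-fold higher number from compound 1 to compound 4 (0.23 log units; within the scatter). For compound 4 the half-life in this assay is estimated at 0.3 h, within a range of 0.1 h to 1 h.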

Compound 4, half-life: 0.758 h
Compound 4: the middle estimate sits 2.5-fold (0.40 log units) below what was measured; measured number inside the range.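

Ethyl to isopropyl is the first change here that can be read on its own, and in this assay it gives a 4.3-fold higher number from compound 1 to compound 4 (0.63 log units; beyond the scatter). One added methyl on a saturated chain carbon bound to an aromatic carbon and a saturated chain carbon is therefore enough to lengthen the half-life beyond the usual scatter of repeated measurements, which shows that this position is not indifferent to small changes. Compound 4 still gives a definite number rather than a limit, so the assay has room to register further gains from this position: the limit of > 3 h in this assay, at which 2 of the 4 values shown sit.

Going by these compounds, whether the half-life keeps lengthening as the group grows remains open, and a tert-butyl group or a longer chain such as propyl would test this. The compounds shown also leave open why the added methyl lengthens the half-life.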